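From an Aromatic Urea Arm to Cyclohexylmethyl

The compounds below may be only part of what the source reports. "The series", "measured", "known", "first", "only" and "open" are said of these compounds alone.

In a functional assay on HCT-116 cells (Homo sapiens) for antiproliferative activity, read by MTT assay, with a stated time of 72 h (on this read-out higher numbers stand for weaker inhibition and lower numbers for stronger inhibition), compound 1 (`O=C(Nc1ccc(Nc2nccc(NC3CCCC3)n2)cc1)Nc1cccc(C(F)(F)F)c1`) gives 2410 nM and compound 2 (`O=C(Nc1ccc(Cl)cc1)Nc1ccc(Nc2nccc(NC3CCCC3)n2)cc1`) gives 5310 nM, so compound 2 holds the higher number of the two and is the weaker inhibitor. Compound 3 (`O=C(CC1CCCCC1)Nc1ccc(Nc2nccc(NC3CCCC3)n2)cc1`) has not yet been measured. It differs from compound 2 on a carbonyl carbon, where cyclohexylmethyl stands in place of (4-chlorophenyl)amino: cyclohexylmethyl in place of (4-chlorophenyl)amino on a carbonyl carbon. An aromatic ring therefore gives way to a non-aromatic one.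

Among the compounds with values here, only one measured step offers guidance, a 2.2-fold higher number from compound 1 to compound 2 (0.34 log units; beyond the scatter). This modest step exchanged 3-(trifluoromethyl)phenyl for 4-chlorophenyl, so an aromatic ring was present on both sides. Within the data shown here, no measured pair shows what happens when cyclohexylmethyl enters, which leaves the direction poorly defined. In this assay, no step beyond the usual scatter is therefore the central expectation, though a wide margin is needed on both sides. The expected change is a 1.1-fold higher number from compound 2 to compound 3 (0.05 log units; within the scatter). For compound 3 the estimated value is 6000 nM, with an expected range from 1800 nM to 20000 nM.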

Compound 3, half-maximal inhibitory concentration: 2440 nM
For compound 3 the middle estimate is 2.5-fold (0.39 log units) above the measured one, and the stated range covers the measured number.
By their numbers in this assay, from the lowest: compounds 1 and 3 (each within the scatter of the next); then compound 2.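

On a carbonyl carbon, the aromatic (4-chlorophenyl)amino group can give way to cyclohexylmethyl with no loss of inhibition in this assay: the change gives a 2.2-fold lower number from compound 2 to compound 3 (0.34 log units; beyond the scatter). Set against the 3-(trifluoromethyl)phenyl urea, the same kind of replacement gives a 1.0-fold higher number from compound 1 to compound 3 (0.01 log units; within the scatter), so among these three compounds, neither an aromatic ring nor a nitrogen on this carbonyl carbon is required to reach the best level seen here. No evidence accompanies these numbers that could explain the result.

The aromatic ring and the nitrogen leave together, so it remains open which of the two accounts for the difference between compound 2 and compound 3, a question that a benzyl group or a cyclohexylamino group on the same carbonyl carbon could help to settle. As far as these compounds go, it is also open how much room this position offers beyond the ring itself, for instance whether a longer chain between the carbonyl carbon and the cyclohexane ring, or an amine or a carboxylic acid on that ring, would keep the activity of compound 3.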